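The source may hold more compounds than are shown below. What is called first, only, known or untested is meant among the compounds shown, and "the series" means these compounds.

Measured in a functional assay on NCI/ADR cells (Homo sapiens) for cytotoxicity, read by sulforhodamine B assay; a lower number here means a stronger inhibitor of growth, a higher number a weaker inhibitor of growth:

- compound 1 `CC1=CC[C@@H]([C@@](C)(O)CCCC(C)(C)NC(=S)N/N=C\c2ccccc2)CC1`: 23800 nM
- compound 2 `COc1ccc(/C=N\NC(=S)NC(C)(C)CCC[C@](C)(O)[C@@H]2CC=C(C)CC2)cc1`: 57000 nM
- compound 3 `CC1=CC[C@@H]([C@@](C)(O)CCCC(C)(C)NC(=S)N/N=C\c2ccc([N+](=O)[O-])cc2)CC1`: > 100000 nM (a limit of the assay, not a number)

Compound 3 has no exact value, only the limit of > 100000 nM. Compound 4 `CC1=CC[C@@H]([C@@](C)(O)CCCC(C)(C)NC(=S)N/N=C\c2ccc(Cl)cc2)CC1` differs from it in one place: chloro in place of nitro on an aromatic carbon. This puts chloro in place of nitro on an aromatic carbon, para to a large group.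

Among the compounds with values here, two measured steps bear on this change, and both start from the unsubstituted compound 1. Methoxy gave a 2.4-fold higher number from compound 1 to compound 2 (0.38 log units; beyond the scatter), and nitro gave an at least 4.2-fold higher number from compound 1 to compound 3 (0.62 log units; beyond the scatter). The comparison of the two substituents, an at least 1.7-fold higher number from compound 2 to compound 3 (0.24 log units; that floor lies within the scatter), does not separate them. Within the data shown here, no chloro compound has been measured, so compound 4 is expected to resemble compound 1 and compound 2 and to fall short of the limit. The expected change is an at least 2.5-fold lower number from compound 3 to compound 4 (0.39 log units; beyond the scatter), a modest move to a lower number. For compound 4 the estimated value is 40000 nM, with an expected range of 15000 nM to 100000 nM.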

Compound 4, concentration for total growth inhibition: 36400 nM
For compound 4 the middle estimate is 1.1-fold (0.04 log units) above the measured one; the range from low to high includes it.
By their numbers in this assay, from the lowest: compounds 1, 4 and 2 (each within the scatter of the next, the first and the last beyond it). At a limit, above all of these: compound 3.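

In this assay, 4-chlorophenyl in place of 4-nitrophenyl gives an at least 2.7-fold lower number from compound 3 to compound 4 (0.43 log units; beyond the scatter), so a substituent at this place, para to a large group, need not push the number to the limit. Chloro does not stand apart from the other two groups: the steps are a 1.5-fold higher number from compound 1 to compound 4 (0.18 log units; within the scatter) and a 1.6-fold lower number from compound 2 to compound 4 (0.19 log units; within the scatter), so these values do not separate it from hydrogen or from methoxy. Compound 3 has only a limit of the assay, not a number: the limit of > 100000 nM in this assay, at which 1 of the 4 values shown sits.

The compounds shown leave open why nitro differs from chloro here, since they show only the outcome of the swap. They also leave open whether an amine, a carboxylic acid or a longer chain at this same place would stay close to compound 1 or reach the limit as well.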